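The source may hold more compounds than are shown below. What is called first, only, known or untested is meant among the compounds shown, and "the series" means these compounds.

Measured compounds:
compound 1, `COc1cc(/C=C/C(=O)/C=C(O)/C=C/c2ccc(O[C@H]3C=C(C)[C@@H](O)C[C@@H]3[C@@H](C)CCC=C(C)C)c(OC)c2)ccc1O`, 27300 nM
compound 2, `COc1cc(/C=C/C(=O)/C=C(O)/C=C/c2ccc(O[C@H]3C[C@H]([C@@H](C)CCC=C(C)C)[C@@H](O)C=C3C)c(OC)c2)ccc1O`, 74900 nM
compound 3, `COc1cc(/C=C/C(=O)/C=C(O)/C=C/c2cc(OC)c(O)c([C@H]3C=C(C)[C@@H](O)C[C@@H]3[C@@H](C)CCC=C(C)C)c2)ccc1O`, 43700 nM

In a functional assay on MDA-MB-231 cells (Homo sapiens) for cytotoxicity, read by crystal violet staining, with a stated time of 72 h (a lower number here means a stronger inhibitor, a higher number a weaker inhibitor), the three measured compounds all give numbers in the same broad region. Compound 1 gives the lowest number of the three; its gap to compound 3 is within the scatter of repeated measurements, while its gap to compound 2 lies beyond the scatter. Among these compounds no pair differs in one place only, so no single step has been measured.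

Compound 4 has the structure `COc1cc(/C=C/C(=O)/C=C(O)/C=C/c2ccc(O[C@H]3C=C(C)[C@@H](O)C[C@@H]3[C@@H](C)CC(=O)C=C(C)C)c(OC)c2)ccc1O`. It differs from compound 1 in one place: (2-methylprop-1-en-1-yl)carbonyl in place of 3-methylbut-2-en-1-yl on a saturated chain carbon, two bonds along the chain from a saturated ring carbon. The change keeps the chain outside any ring and adds one hydrogen-bond acceptor there.

Nothing measured here shows how such a change in this side chain moves the number in this assay. The step is therefore expected to be small, in either direction, and most likely to stay within the scatter: the expected step of a 1.0-fold lower number from compound 1 to compound 4 (0.00 log units; within the scatter). Compound 4 is accordingly estimated at 27000 nM, with a range from 9000 nM to 80000 nM.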

Compound 4, half-maximal inhibitory concentration: 10600 nM
Compound 4: the middle estimate sits 2.5-fold (0.41 log units) above what was measured; the measured number falls inside the stated range.
By their numbers in this assay, from the lowest: compound 4; then compounds 1, 3 and 2 (each within the scatter of the next, the first and the last beyond it).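

Going by these compounds alone, the side chain at this place, on a saturated chain carbon, two bonds along the chain from a saturated ring carbon, is not silent in this assay: (2-methylprop-1-en-1-yl)carbonyl in place of 3-methylbut-2-en-1-yl gives a 2.6-fold lower number from compound 1 to compound 4 (0.41 log units; beyond the scatter) and so provides the first single change in the set. The earlier compounds shown here, with no pair differing in one place only, could not show that this part of the molecule moves the number at all. No measurement at hand explains the step.

The compounds shown do not separate the carbonyl from the added double bond, as both enter together in compound 4. They also leave open whether the same change would move the number on compound 2 or compound 3, and how an amine, a hydroxyl group or a longer chain would read at this place.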